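The source may report more compounds than this note shows. Statements on the series, on what has been measured and on what is new or still open speak of the compounds shown alone.

Three compounds built on the same core differ only in the group carried on the amide nitrogen. Compound 1 `CC(C)n1ncc2c(C(=O)NC3CCCC3)cccc21` bears a cyclopentyl there. In a functional assay on MCF7 cells (Homo sapiens) for inhibition, read by MTT assay, with a stated time of 72 h (on this read-out lower numbers stand for stronger inhibition and higher numbers for weaker inhibition), compound 1 gives no number but only a limit of the assay, > 40000 nM. Compound 2 `CC(C)n1ncc2c(C(=O)NCc3ccccc3)cccc21` bears a benzyl in place of the cyclopentyl. In this assay compound 2 likewise reaches only a limit, > 40000 nM. The step that the two limits leave unreadable from compound 1 to compound 2 is therefore unreadable. Compound 3 `CC(C)n1ncc2c(C(=O)NCc3cn(-c4ccccc4)nn3)cccc21` carries a third, larger group on that nitrogen. In this assay compound 3 again stands only at a limit, > 40000 nM. Among the compounds with values here, all three values shown sit at the same limit (the limit of > 40000 nM in this assay, at which 3 of the 3 values shown sit), so no measured step has a readable size, and compound 3 is known only to lie at or beyond that limit.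

Compound 4 `Cc1ccc(-n2cc(CNC(=O)c3cccc4c3cnn4C(C)C)nn2)cc1C` differs from compound 3 by 3,4-dimethylphenyl in place of phenyl on an aromatic nitrogen. Within the data shown here, no measured step bears on this change, and the one step that exists cannot be read in either direction. On these numbers compound 4 is expected to remain at the limit, and the expected step of a number no higher from compound 3 to compound 4 (the limit leaves the size open) is none beyond the scatter. Compound 4 is therefore estimated at 40000 nM, with a range from 10000 nM to 100000 nM.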

Compound 4, half-maximal inhibitory concentration: > 40000 nM
Compound 4 ended at the assay's limit; the forecaster's own chance of this, stated with the estimate: 80%; the middle value lies on the limit itself.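

Compound 3 and compound 4 both stand only at a limit of this assay and give no number, so no step between them can be read: the limit of > 40000 nM in this assay, at which 4 of the 4 values shown sit.

The compounds shown leave open how strongly any of them inhibits in this assay, and whether the group on the amide nitrogen or the phenyl substitution makes any difference.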